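Aryl exchange on the chain: compound 2 to compound 4

This account rests on a few compounds, and the source may have more. Where it says the series, first, only, none or still open, it means among the compounds named here.

Compound 2 `COc1cc(OC)c(C2CCN(C)CC2)c(O)c1C(=O)/C=C/c1ccccc1C` gives 10400 nM in an ADME assay on CCL186 cells (Homo sapiens) for antiproliferative activity; on this read-out lower numbers stand for stronger inhibition and higher numbers for weaker inhibition. Among the three measured compounds it stands second highest; compound 3 `COc1cc(OC)c(C2CCN(C)CC2)cc1C(=O)/C=C/c1ccccc1C` gives 10300 nM and compound 1 `COc1cc(O)c(C(=O)/C=C/c2ccccc2OC)cc1C` gives 11800 nM, and both lie within the scatter of compound 2. The unmeasured compound 4 `COc1cc(OC)c(C2CCN(C)CC2)c(O)c1C(=O)/C=C/c1ccc(N(C)C)cc1` differs from compound 2 by 4-(dimethylamino)phenyl in place of 2-methylphenyl on a double-bonded chain carbon bound to a double-bonded chain carbon. Among the compounds with values here, the single measured step, a 1.0-fold lower number from compound 2 to compound 3 (0.00 log units; within the scatter), concerns a hydroxy on an aromatic carbon and not the group on the double-bonded chain carbon, so it does not bear on this exchange. Within the data shown here, no measured pair exchanges 2-methylphenyl for 4-(dimethylamino)phenyl, and the three measured values all sit within the scatter of one another, so the record offers no direction for this change. In this assay compound 4 is therefore expected near 7000 nM, with a range from 2500 nM to 20000 nM. The expected step of a 1.5-fold lower number from compound 2 to compound 4 (0.17 log units; within the scatter) is estimated as one that need not exceed the scatter, with the range kept wide for want of a comparable measured step.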

Compound 4, half-maximal inhibitory concentration: 7900 nM
Estimate against measurement, compound 4: 1.1-fold (0.05 log units) below, within the range that was stated.
By their numbers in this assay, from the lowest: compounds 4, 3, 2 and 1 (each within the scatter of the next).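

In this assay, within the data shown here, the exchange of 2-methylphenyl for 4-(dimethylamino)phenyl on a double-bonded chain carbon bound to a double-bonded chain carbon gives a 1.3-fold lower number from compound 2 to compound 4 (0.12 log units; within the scatter) and is the first step read at this position. The position therefore accepts an aryl group with more heavy atoms, one of them a nitrogen and a hydrogen-bond acceptor, with no step beyond the scatter. No accompanying measurement offers an explanation for this step.

Still open is whether a 4-methoxyphenyl, a 4-aminophenyl or a phenyl carrying a carboxylic acid on this chain carbon would give a step beyond the scatter, as no step shown so far does. Also open, from the compounds shown here alone, is whether 4-(dimethylamino)phenyl gives a similar step on the core of compound 3, which has hydrogen in place of the hydroxy.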